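This account rests on a few compounds, and the source may have more. Where it says the series, first, only, none or still open, it means among the compounds named here.

Compound 1 `COc1ccc(Nc2nc(-c3cccc(F)c3)nc3ccc(F)cc23)cc1`: 32300 nM
Compound 2 `Cc1ccc(Nc2nc(-c3cccc(F)c3)nc3ccc(F)cc23)cc1`: > 50000 nM

Both compounds were tested in a functional assay on U2OS cells (Homo sapiens) for cytotoxicity, read by MTT assay, with a stated time of 48 h (on this read-out lower numbers stand for stronger inhibition and higher numbers for weaker inhibition), where compound 1 gives 32300 nM. Compound 2 is recorded only as a limit, > 50000 nM, so it has no exact number. Compound 3 `Cc1cccc(Nc2nc(-c3cccc(F)c3)nc3ccc(F)cc23)c1` keeps the same atoms as compound 2 but has 3-methylphenyl in place of 4-methylphenyl on a nitrogen on an aromatic ring. Among the measured compounds shown here, only one measured step bears on this change, and only loosely: an at least 1.5-fold higher number from compound 1 to compound 2 (0.18 log units; that floor lies within the scatter). That step swaps methyl in place of methoxy on an aromatic carbon, not the 4-methylphenyl for the 3-methylphenyl, and it gives no direction for the new change. No step beyond the scatter is therefore expected in this assay. The expected change is an at least 1.1-fold lower number from compound 2 to compound 3 (0.07 log units; that floor lies within the scatter). For compound 3 the estimated value is 42000 nM, with an expected range from 18000 nM to 70000 nM.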

Compound 3, half-maximal inhibitory concentration: > 50000 nM
Compound 3 gave a limit, no number; the forecaster's own chance of this, stated with the estimate: 55%; at least 1.1-fold (0.07 log units) between middle value and limit.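

In this assay compound 3 gives > 50000 nM as a limit and not a number, so with 3-methylphenyl in place of 4-methylphenyl on this nitrogen the read-out still yields no exact value. The step between compound 2 and compound 3 cannot be read, because both are recorded only at the limit: the limit of > 50000 nM in this assay, at which 2 of the 3 values shown sit. Measured against the 4-methoxyphenyl group, the new compound shows an at least 1.5-fold higher number from compound 1 to compound 3 (0.18 log units; that floor lies within the scatter) and so, like the methyl change before it, gives a floor that does not clear the scatter.

As far as these compounds go, the true values of compound 2 and compound 3 remain open, and so does any ranking of the two methyl placements. Also open, from the compounds shown here alone, is whether an amine or a carboxylic acid on this phenyl ring would give a lower number than compound 1 does.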